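Methyl in Place of Hydrogen on a Shared Core

The source may report more compounds than this note shows. Statements on the series, on what has been measured and on what is new or still open speak of the compounds shown alone.

Compound 1 `COc1cccc(COc2ccccc2/C=C/C=C2\SC(=S)NC2=O)c1` and compound 2 `O=C1NC(=S)S/C1=C\C=C\c1ccccc1OCc1ccccc1` share one core. In an assay on isolated protein for inhibition of protein tyrosine phosphatase type IVA 3 (Homo sapiens), tested at 5 ug/mL (a lower number here means less inhibition, a higher number more inhibition at the concentration tested (going by the name of the read-out)), compound 1 gives 52.9%, and compound 2 gives 49.5%; the step of a number 3.4 percentage points lower from compound 1 to compound 2 (within the scatter) lies within the scatter, so the two numbers cannot be told apart. Compound 3 `Cc1ccccc1COc1ccccc1/C=C/C=C1\SC(=S)NC1=O` differs from compound 2 by methyl in place of hydrogen on an aromatic carbon. Among the compounds with values here, no measured step swaps hydrogen for methyl, and the only known step was small, so in this assay compound 3 is expected to give 50%, between 35% and 65%. The expected step of a number 0.5 percentage points higher from compound 2 to compound 3 (within the scatter) would stay within the scatter.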

Compound 3, a percentage reported as inhibition, at one concentration (the size of the read-out at that concentration, not a potency): 52.8%
Compound 3: the middle estimate sits 2.8 percentage points below what was measured; low and high end bracket the measured number.
By their numbers in this assay, from the lowest: compounds 2, 3 and 1 (each within the scatter of the next).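

Methyl in place of hydrogen on this aromatic carbon, ortho to a large group, reads as a number 3.3 percentage points higher from compound 2 to compound 3 (within the scatter) in this assay and so leaves no readable difference. Setting 2-methylphenyl in place of 3-methoxyphenyl gives a number 0.1 percentage points lower from compound 1 to compound 3 (within the scatter), so this ring has so far carried hydrogen, methyl or methoxy with no difference that can be told apart. No available evidence bears on this result. On these data alone, whether an amine, a carboxylic acid or a longer chain on this ring would read differently remains open.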